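The source may report more compounds than this note shows. Statements on the series, on what has been measured and on what is new or still open speak of the compounds shown alone.

Compound 1 `Cc1cccc(-c2nc3cc(C)ccc3c(=O)[nH]2)c1` was examined in an assay on isolated protein for inhibition of DNA topoisomerase 1 (Homo sapiens), with a stated time of 30 min, tested at 100 uM (on this read-out lower numbers stand for a weaker effect and higher numbers for a stronger effect at the one concentration tested), where compound 1 gives 100%. That is the highest of the two numbers recorded so far. The nearest is compound 2 `COc1cccc(-c2nc3ccc(C)cc3c(=O)[nH]2)c1`, which in this assay gives 71.8%, and the gap between the two readings lies beyond the usual scatter of this kind of measurement. Within the data shown here, no step between two measured compounds that differ in a single place has been worked out, so these two values stand on their own and describe no trend.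

Compound 3 `Cc1ccc2c(=O)[nH]c(-c3cccc(F)c3)nc2c1` has not yet been measured. It differs from compound 1 in one place: fluoro in place of methyl on an aromatic carbon. Among the measured compounds shown here, the shared core of compound 1 is unchanged, and only this one group is exchanged.

Compound 1 sits at 100%, so there is no room above it. The step is expected to be a modest downward one, a number 15 percentage points lower from compound 1 to compound 3 (beyond the scatter), close to the edge of the scatter rather than far beyond it. Compound 3 is estimated to give 85% in this assay, with a range from 55% to 100%.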

Compound 3, a percentage reported as inhibition, at one concentration (the size of the read-out at that concentration, not a potency): 77.5%
Compound 3: middle estimate off by 7.5 percentage points, on the high side; measured number inside the range.
By their numbers in this assay, from the lowest: compounds 2 and 3 (each within the scatter of the next); then compound 1.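

Among these compounds, this is the first pair in the set that differs in one place only, so a single change can now be read on its own: in this assay, putting fluoro in place of methyl on an aromatic carbon, meta to a large group, gives a number 22.5 percentage points lower from compound 1 to compound 3 (beyond the scatter) on the same shared core. The position is therefore sensitive to which small group it carries, but the methyl is not required for a clear effect, since compound 3 still gives 77.5% at the one concentration tested. Nothing available explains why the reading falls with this exchange.

Going by these compounds, a single pair gives only two points at this carbon, so it remains open whether the reading would hold, fall further or recover with another group there, such as chloro, an amine or a carboxylic acid. On these data alone, it also remains open how compound 1 and compound 3 would compare at other concentrations, as compound 3 shows a weaker effect than compound 1 only at the one concentration tested.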